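Removing the tolyl methyl on a benzimidazolylmethyl sulfonamide

The compounds below may be only part of what the source reports. "The series", "measured", "known", "first", "only" and "open" are said of these compounds alone.

Three sulfonamides have been measured in a functional assay on MGC-803 cells (Homo sapiens) for inhibition, read by MTT assay, with a stated time of 48 h; a lower number here means a stronger inhibitor, a higher number a weaker inhibitor. Compound 1 `COc1cc(N(Cc2cccc(C)c2)S(=O)(=O)c2ccc(C)cc2)cc(OC)c1OC` gives 4340 nM. Compound 2 `COc1cc(N(Cc2ccccc2)S(=O)(=O)c2ccc(C)cc2)cc(OC)c1OC` gives 3570 nM, and compound 3 `COc1cc(N(Cc2nc3ccccc3[nH]2)S(=O)(=O)c2ccc(C)cc2)cc(OC)c1OC` gives 1020 nM, the lowest of the three numbers, with a 3.5-fold lower number from compound 2 to compound 3 (0.54 log units; beyond the scatter) and a 4.3-fold lower number from compound 1 to compound 3 (0.63 log units; beyond the scatter). The cores of compound 1 and compound 3 differ in one place: 1H-benzimidazol-2-yl in place of 3-methylphenyl on a saturated chain carbon bound to a sulfonamide nitrogen.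

One change recurs. From compound 1 to compound 2 it reads (hydrogen in place of methyl on an aromatic carbon), and its step in this assay was a 1.2-fold lower number from compound 1 to compound 2 (0.08 log units; within the scatter). Compound 4 `COc1cc(N(Cc2nc3ccccc3[nH]2)S(=O)(=O)c2ccccc2)cc(OC)c1OC`, not yet measured, carries the same kind of change from compound 3, (hydrogen in place of methyl on an aromatic carbon); around the place it differs, since the methyl of compound 1 sits meta to a large group whereas that of compound 3 sits para to a large group, and on the other end of the molecule.

Because a 1.2-fold lower number from compound 1 to compound 2 (0.08 log units; within the scatter) stayed within the scatter, the step from compound 3 to compound 4 is expected to be similarly small, a 1.1-fold lower number from compound 3 to compound 4 (0.03 log units; within the scatter). Compound 4 is therefore estimated at 950 nM, between 480 nM and 1900 nM.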

Compound 4, half-maximal inhibitory concentration: 12400 nM
Compound 4: middle estimate off by 13-fold (1.12 log units), on the low side, outside the stated range (above it).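

In this assay, taking the methyl off the 4-methylphenyl group of compound 3 gave a 12-fold higher number from compound 3 to compound 4 (1.08 log units; beyond the scatter), so this change did not carry over from one core to the other, and the two steps differ clearly: the same change on two cores in this assay, a 1.2-fold lower number (0.08 log units; within the scatter) from compound 1 to compound 2 and a 12-fold higher number (1.08 log units; beyond the scatter) from compound 3 to compound 4, 15-fold (1.17 log units) apart, beyond the scatter of two such steps. On this core the methyl of the (4-methylphenyl)sulfonyl group therefore counts for much, whereas the methyl of the 3-methylphenyl group of compound 1 showed no effect beyond the scatter. The comparison does not show whether the gap comes from the core or from the place of the methyl, as the two steps differ in both, and a single pair on each core gives no general rule for this series.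

On these data alone, whether the loss seen in compound 4 also appears on the core of compound 2 remains open. So does whether an ethyl group or a chlorine atom in the place of that methyl would give a number like that of compound 3 or one like that of compound 4.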